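A few compounds are considered here, and "the series" means these few. Any claim that something is new, unique, unknown or untested is made for them only; others in the source may bear on it.

Measured compounds in an ADME assay on Vero cells (Chlorocebus sabaeus) for cytotoxicity, read by MTT assay, with a stated time of 72 h; a higher number here means that more compound is tolerated, a lower number that less compound is tolerated:

Compound 1 `COC(=O)c1cc(-c2cccc(NC(=O)c3ccc(C4OC4C(=O)c4ccc(Cl)cc4)cc3)c2)on1` is reported only as a limit in this assay, > 20 ug/mL.

Compound 2 `COC(=O)c1cc(-c2cccc(NC(=O)c3ccc(/C=C/C(=O)c4cc(OC)c(OC)c(OC)c4)cc3)c2)on1` is likewise reported only as a limit in this assay, > 50 ug/mL.

Compound 3 `CC(C)Cc1ccc(C(=O)/C=C/c2ccc(C(=O)O)cc2)cc1` is reported as a limit in this assay as well, < 10 ug/mL.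

None of the three values is a number; each is a limit of this assay, so compound 2 stands at the limit of the limit of > 50 ug/mL in this assay, at which 1 of the 3 values shown sits, compound 1 at the limit of the limit of > 20 ug/mL in this assay, at which 1 of the 3 values shown sits, and compound 3 at the limit of the limit of < 10 ug/mL in this assay, at which 1 of the 3 values shown sits. Among the compounds with values here, no step between measured compounds can be computed from limits alone.

Compound 4 `CCCOc1ccc(C(=O)/C=C/c2ccc(C(=O)Nc3cccc(-c4cc(C(=O)OC)no4)c3)cc2)cc1` has not yet been measured in this assay. It differs from compound 2 in one place: 4-propoxyphenyl in place of 3,4,5-trimethoxyphenyl on a carbonyl carbon whose other neighbour is a double-bonded chain carbon.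

Since compound 2 sits at a limit, the step of a number no higher from compound 2 to compound 4 (the limit leaves the size open) is expected to stay within the usual scatter, with no change in direction beyond it. Compound 4 is therefore expected to give about 50 ug/mL, in a range from 20 ug/mL to 100 ug/mL, most likely again reported as a limit rather than a number.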

Compound 4, half-maximal cytotoxic concentration: > 40 ug/mL
Compound 4: no number, only a limit; the forecaster's own chance of this, stated with the estimate: 60%; the middle value is on the limit's open side.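

In this assay compound 4 is reported only as a limit, > 40 ug/mL. Within the data shown here, compound 2 is likewise known only as a limit, and no step between compound 2 and compound 4 can be read. The compounds shown leave open whether 4-propoxyphenyl in place of 3,4,5-trimethoxyphenyl changes tolerance at all.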